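Dropping the benzoyl group: from compound 2 to compound 3

A few compounds are considered here, and "the series" means these few. Any claim that something is new, unique, unknown or untested is made for them only; others in the source may bear on it.

Compound 1 `CCCCCCCCC(=O)N1c2ccccc2CCC1C(=O)Nc1ccccc1O` and compound 2 `O=C(Nc1ccccc1O)C1CCc2ccccc2N1C(=O)c1ccccc1` share one core and differ only on a carbonyl carbon. In a functional assay on PC-3 cells (Homo sapiens) for cytotoxicity, read by sulforhodamine B assay, with a stated time of 72 h (a lower number here means a stronger inhibitor of growth, a higher number a weaker inhibitor of growth), compound 1 gives 45200 nM and compound 2 gives 5690 nM, the lower of the two numbers. Among the measured compounds shown here, the only measured step is a 7.9-fold lower number from compound 1 to compound 2 (0.90 log units; beyond the scatter). Compound 3 `O=C(Nc1ccccc1O)C1CCc2ccccc2N1` goes further: hydrogen in place of benzoyl on a nitrogen on an aromatic ring in a ring. For the measured compounds named here, no measured step removes an acyl group outright, so the guidance is indirect. Because the group on that carbonyl mattered in a 7.9-fold lower number from compound 1 to compound 2 (0.90 log units; beyond the scatter), its complete loss is expected to give a weaker inhibitor in this assay, a step of a 3.5-fold higher number from compound 2 to compound 3 (0.55 log units; beyond the scatter). Compound 3 is estimated at 20000 nM, with a range from 5000 nM to 80000 nM.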

Compound 3, concentration for 50% growth inhibition: 4310 nM
Estimate against measurement, compound 3: 4.6-fold (0.67 log units) above; measured number outside the range, below it.
By their numbers in this assay, from the lowest: compounds 3 and 2 (each within the scatter of the next); then compound 1.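

In this assay, this nitrogen keeps its growth inhibition without any acyl group: hydrogen in place of benzoyl gives a 1.3-fold lower number from compound 2 to compound 3 (0.12 log units; within the scatter) and so no real change. Hydrogen in place of octylcarbonyl gives a 10-fold lower number from compound 1 to compound 3 (1.02 log units; beyond the scatter) and thus a clear gain, so among these three compounds it is the octylcarbonyl group that stands apart, not the presence of an acyl group as such. No measurement here explains this result. From the compounds shown here alone, whether a small acetyl or methyl group on this nitrogen would behave like hydrogen or like octylcarbonyl remains open.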